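The compounds below may be only part of what the source reports. "The series", "measured", "known", "first", "only" and "open" are said of these compounds alone.

Compound 1 `C/C=C1/[C@H](O[C@@H]2O[C@H](CO)[C@@H](O)[C@H](O)[C@H]2O)OC=C(C(=O)OC)[C@H]1CC(=O)OCCc1ccc(O)cc1`: in a functional assay on SK-BR-3 cells (Homo sapiens) for antiproliferative activity, read by MTT assay, with a stated time of 72 h (a lower number here means a stronger inhibitor, a higher number a weaker inhibitor), compound 1 gives > 20000 nM, a limit of the assay rather than a number.
Compound 2 `C/C=C1/[C@H](O[C@@H]2O[C@H](CO)[C@@H](O)[C@H](O)[C@H]2O)OC=C(C(=O)OC)[C@H]1CC(=O)O`: in this assay compound 2 gives > 15000 nM, likewise a limit.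
Compound 3 `C/C=C1/[C@H](O[C@@H]2O[C@H](CO)[C@@H](O)[C@H](O)[C@H]2O)OC=C(C(=O)OC)[C@H]1CC(=O)OCCc1ccc(F)cc1`: in this assay compound 3 gives > 20000 nM, again a limit.

Going by the values given here, compound 3 thus stands at a limit, and the two other values shown are limits as well, so no measured compound sets a number to compare against. The three steps among them, a step that the two limits leave unreadable from compound 1 to compound 2, a step that the two limits leave unreadable from compound 1 to compound 3 and a step that the two limits leave unreadable from compound 2 to compound 3, are all unreadable for this reason: one value sits at the limit of > 15000 nM in this assay, at which 1 of the 3 values shown sits, and two sit at the limit of > 20000 nM in this assay, at which 2 of the 3 values shown sit, and nothing can be read between two limits.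

Compound 4 `C/C=C1/[C@H](O[C@@H]2O[C@H](CO)[C@@H](O)[C@H](O)[C@H]2O)OC=C(C(=O)OC)[C@H]1CC(=O)OCCCC` differs from compound 3 by ethyl in place of 4-fluorophenyl on a saturated chain carbon, two bonds along the chain from an oxygen next to a carbonyl group. None of the measured steps gives a readable size, so there is no evidence of any change in this assay from shedding a ring in favour of a short chain, and the shared core has shown no measurable activity in any of the three compounds. The step that the limit leaves unreadable from compound 3 to compound 4 is therefore expected to be none beyond the scatter, most likely ending at a limit once more. Compound 4 is estimated at 25000 nM, within 10000 nM to 60000 nM.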

Compound 4, half-maximal inhibitory concentration: > 15000 nM
Compound 4 gave a limit, no number (the forecaster's own chance of this, stated with the estimate: 85%); the middle value lies beyond the limit too.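

Compound 4 gives only a limit, as do compound 1, compound 2 and compound 3, so none of the steps linking compound 4 to those three can be read. The compounds shown leave open whether butyl, 2-(4-fluorophenyl)ethyl, 2-(4-hydroxyphenyl)ethyl or hydrogen makes any difference in this assay, since no compound here gives an actual number.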